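Ring hydroxy on compound 3: expected shift in dose

This account rests on a few compounds, and the source may have more. Where it says the series, first, only, none or still open, it means among the compounds named here.

Among the compounds with values here, in a functional assay on the whole organism (strain Hartley) for inhibition, with Cavia porcellus as the target, with stated times of 15 min and 2 min (on this read-out lower numbers stand for an effect already at smaller amounts and higher numbers for an effect only at larger amounts of compound), compound 3 `CCCCC1([C@H](O)/C=C/C2CCC(=O)[C@@H]2CCCCCCC(=O)O)CCC1` gives 47.8 mg/kg, the highest of the three numbers so far and beyond the scatter of both others. Compound 1 `CCCCC1([C@@H](O)/C=C/C2[C@H](O)CC(=O)[C@@H]2CCCCCCC(=O)O)CCC1` gives 0.03 mg/kg, and compound 2 `CCCCC1([C@H](O)/C=C/C2[C@H](O)CC(=O)[C@@H]2C/C=C\CCCC(=O)O)CCC1` gives 0.00106 mg/kg.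

Compound 4 `CCCCC1([C@H](O)/C=C/C2[C@H](O)CC(=O)[C@@H]2CCCCCCC(=O)O)CCC1` follows from compound 3 by one change: hydroxy in place of hydrogen on a saturated ring carbon. Within the data shown here, no measured pair isolates this change, since compound 1 and compound 2 each differ from compound 3 in more than one place. Both nevertheless carry the ring hydroxy that compound 3 lacks, and both sit far lower on this assay, with compound 1 at 0.03 mg/kg and compound 2 at 0.00106 mg/kg. A large drop, well beyond the scatter, is therefore expected, and the size remains uncertain. The expected step is a 2400-fold lower number from compound 3 to compound 4 (3.38 log units; beyond the scatter). For compound 4, the estimate is 0.02 mg/kg, with an expected range of 0.002 mg/kg to 0.3 mg/kg.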

Compound 4, dose for half-maximal effect: 0.00145 mg/kg
Compound 4: middle estimate off by 14-fold (1.14 log units), on the high side, and the stated range ends above it.
By their numbers in this assay, from the lowest: compounds 2 and 4 (each within the scatter of the next); then compound 1; then compound 3.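

With this assay as the read-out, hydroxy in place of hydrogen on a saturated ring carbon now stands as an isolated change, giving a 33000-fold lower number from compound 3 to compound 4 (4.52 log units; beyond the scatter), a large step beyond the scatter. The side chain makes no readable difference beside it: 5-carboxypentyl in place of 5-carboxypent-1-en-1-yl gives a 1.4-fold higher number from compound 2 to compound 4 (0.14 log units; within the scatter), which lies within the scatter. The saturated chain carbon bearing the other hydroxy also counts, with a 21-fold lower number from compound 1 to compound 4 (1.32 log units; beyond the scatter), although reading this as a clean swap of configuration is limited by how the pair is drawn: the fact that one of compounds 1 and 4 is drawn with a defined configuration and the other without, at the place where they differ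

The compounds shown leave open whether a methoxy group or a fluorine atom on that ring carbon would hold the dose of compound 4. From the compounds shown here alone, the opposite configuration at the ring hydroxy also remains open, as compounds 1, 2 and 4 all share one drawing there.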